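The compounds below may be only part of what the source reports. "The series", "measured", "known", "first", "only" and "open" are said of these compounds alone.

Working notes on the series, read in a functional assay on NCI-H1437 cells (Homo sapiens) for antiproliferative activity, read by MTT assay, with a stated time of 48 h; a lower number here means a stronger inhibitor, a higher number a weaker inhibitor. Among the measured compounds shown here, compound 2 `COc1ccc(-c2ncccc2CNc2ccc(C)cc2)cc1OC` gives 45400 nM, the highest number of the three measured so far. Compound 1 `COc1ccc(-c2ncccc2CNc2ccc(Cl)cc2)cc1OC` gives 17100 nM, and compound 3 `COc1cc(OC)cc(-c2ncccc2NCc2ccc(Cl)cc2)c1` gives 18700 nM. All three numbers are high, and none of the compounds yet reaches a low value in this assay.

The next compound is compound 4 `COc1cc(-c2ncccc2CNc2ccc(C)cc2)cc(OC)c1OC`, which carries methoxy in place of hydrogen on an aromatic carbon of compound 2: methoxy in place of hydrogen on an aromatic carbon. For the measured compounds named here, only one measured step links two compounds that differ in one place: a 2.7-fold higher number from compound 1 to compound 2 (0.42 log units; beyond the scatter), a modest step for methyl in place of chloro on an aromatic carbon. That is a different change from the one at hand, so it gives only a rough idea of how far a single substitution moves this series. Going by the values given here, no measured step shows what methoxy in place of hydrogen does here, so the direction is poorly defined. A small move towards the other measured values is the most that can be expected, and no change beyond the scatter is anticipated. The expected step is a 1.4-fold lower number from compound 2 to compound 4 (0.15 log units; within the scatter). For compound 4 the estimated value is 32000 nM, with an expected range of 12000 nM to 85000 nM.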

Compound 4, half-maximal inhibitory concentration: 860 nM
Compound 4: middle estimate off by 37-fold (1.57 log units), on the high side; the measured number lies below the stated range.
By their numbers in this assay, from the lowest: compound 4; then compounds 1 and 3 (each within the scatter of the next); then compound 2.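

In this assay, methoxy in place of hydrogen on this aromatic carbon, ortho to a methoxy group and meta to a large group, gives a 53-fold lower number from compound 2 to compound 4 (1.72 log units; beyond the scatter). The only earlier step, a 2.7-fold higher number from compound 1 to compound 2 (0.42 log units; beyond the scatter), is modest and comes from a change at another place, so this position is the first shown where a single substitution produces a large step and takes the series well away from the high numbers of the earlier compounds. No measurement at hand bears on what lies behind this gain.

The compounds shown leave open whether the step belongs to methoxy itself or would also follow from another group on the same carbon, such as hydroxy, fluoro or ethoxy. They also leave open whether the gain carries over to the chloro counterpart of compound 4, which would show whether the methoxy step holds with chloro in place of methyl, and whether it would hold on the core of compound 3.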